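Moving a Methoxy Group and Methylating an Amide: Compound 4

A few compounds are considered here, and "the series" means these few. Any claim that something is new, unique, unknown or untested is made for them only; others in the source may bear on it.

Compound 1 `COc1ccc(-c2cccc(C(=O)N(C)C)c2)cc1S(=O)(=O)Nc1ccc2ccc(NC(=O)c3ccccc3)cc2c1`: in a functional assay on CHO cells for agonist activity at Orexin/Hypocretin receptor type 1 (Homo sapiens) (on this read-out higher numbers stand for an effect only at larger amounts of compound and lower numbers for an effect already at smaller amounts), compound 1 gives > 10000 nM, which is a limit of the assay and not a number.
Compound 2 `COc1ccc(-c2cccc(C(=O)N(C)C)c2)cc1S(=O)(=O)Nc1ccc2ccc(N(C)C(=O)c3ccccc3)cc2c1`: in this assay compound 2 gives > 10000 nM, again a limit of the assay.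
Compound 3 `COc1cccc(C(=O)Nc2cccc3ccc(NS(=O)(=O)c4cc(-c5cccc(C(=O)N(C)C)c5)ccc4OC)cc23)c1`: in this assay compound 3 gives 473 nM.

For the measured compounds named here, compound 3 therefore stands as the only compound with a true number in this assay; the other two values are limits, as the limit of > 10000 nM in this assay, at which 2 of the 3 values shown sit, records. The step that the two limits leave unreadable from compound 1 to compound 2 cannot be read, since both ends sit at the limit, so it gives no size for adding a methyl to an amide-type nitrogen.

Compound 4 `COc1ccc(C(=O)N(C)c2cccc3ccc(NS(=O)(=O)c4cc(-c5cccc(C(=O)N(C)C)c5)ccc4OC)cc23)cc1` differs from compound 3 in one place: ((4-methoxyphenyl)carbonyl)(methyl)amino in place of ((3-methoxyphenyl)carbonyl)amino on an aromatic carbon. Going by the values given here, this change combines the same kind of methylation with a move of the methoxy group, and no measured step gives its size. Compound 4 is therefore expected to be weaker than compound 3, with the step of a 3.2-fold higher number from compound 3 to compound 4 (0.50 log units; beyond the scatter) estimated only loosely. The value of compound 4 in this assay is estimated at 1500 nM, within 300 nM to 10000 nM.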

Compound 4, half-maximal effective concentration: 654 nM
The estimate for compound 4 lay 2.3-fold (0.36 log units) above the measured number, and the stated range covers the measured number.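

In this assay, replacing ((3-methoxyphenyl)carbonyl)amino with ((4-methoxyphenyl)carbonyl)(methyl)amino on this aromatic carbon gives a 1.4-fold higher number from compound 3 to compound 4 (0.14 log units; within the scatter), so compound 3 and compound 4 cannot be told apart. This pair therefore shows that a real number in this assay survives the loss of the amide hydrogen at this position, together with the shift of the methoxy group. The earlier methylation step cannot be read, and only compound 3 and compound 4 give true numbers, while the other two compounds give only a limit of the assay: the limit of > 10000 nM in this assay, at which 2 of the 4 values shown sit.

The compounds shown do not separate the added methyl from the moved methoxy group, since both differ together in this pair. They also leave open how an amine or a carboxylic acid in place of the methoxy group would read out in this assay.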